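Bicyclic amines: heteroaryl swap and tolerated concentration

The source may report more compounds than this note shows. Statements on the series, on what has been measured and on what is new or still open speak of the compounds shown alone.

Measured so far in an ADME assay on MDCK cells (Canis lupus familiaris) for cytotoxicity, read by microscopy, with a stated time of 48 h; a lower number here means that less compound is tolerated, a higher number that more compound is tolerated:
compound 1 `C[C@H]1[C@H](NCc2cncnc2)C[C@H]2C[C@@H]1C2(C)C`: > 100000 nM
compound 2 `C[C@H]1[C@H](NCc2ccoc2)C[C@H]2C[C@@H]1C2(C)C`: > 100000 nM
compound 3 `C[C@H]1[C@H](NCc2ccc(Br)s2)C[C@H]2C[C@@H]1C2(C)C`: 43000 nM

Compound 1 gives only a limit, > 100000 nM. Compound 2 likewise gives only a limit, > 100000 nM. Among the compounds with values here, compound 3 gives 43000 nM, the only actual number among the three. The values of compound 1 and compound 2 sit at a limit, (the limit of > 100000 nM in this assay, at which 2 of the 3 values shown sit). Compound 4 `C[C@H]1[C@H](NCc2cnccn2)C[C@H]2C[C@@H]1C2(C)C` differs from compound 3 by pyrazin-2-yl in place of 5-bromothiophen-2-yl on a saturated chain carbon bound to an amine nitrogen. Within the data shown here, the steps that bear on this change are an at least 2.3-fold lower number from compound 1 to compound 3 (0.36 log units; beyond the scatter) and an at least 2.3-fold lower number from compound 2 to compound 3 (0.36 log units; beyond the scatter); compound 4 carries a six-membered aromatic ring, as compound 1 does, so the move is expected to run back the other way. The expected step is a 2.3-fold higher number from compound 3 to compound 4 (0.37 log units; beyond the scatter). Compound 4 is estimated at 100000 nM, between 40000 nM and 300000 nM, and may itself be reported only as a limit.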

Compound 4, minimum cytotoxic concentration: > 100000 nM
Compound 4 ended at the assay's limit; the forecaster's own chance of this, stated with the estimate: 60%; the middle value lies on the limit itself.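

In this assay, pyrazin-2-yl in place of 5-bromothiophen-2-yl gives an at least 2.3-fold higher number from compound 3 to compound 4 (0.36 log units; beyond the scatter), the first step read out of compound 3 towards a six-membered aromatic ring with 2 hetero atoms that starts from a different ring than the pyrimidin-5-yl of compound 1. Within the data shown here, compound 3 remains the only compound of the four with an actual number. The steps among compound 1, compound 2 and compound 4 cannot be read, all three values being limits: the limit of > 100000 nM in this assay, at which 3 of the 4 values shown sit.

From the compounds shown here alone, the shares of the bromine and the thiophene ring in compound 3 stay open. A plain thiophen-2-yl or a 5-chlorothiophen-2-yl at this place would bear on that.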